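The source may report more compounds than this note shows. Statements on the series, on what has been measured and on what is new or still open speak of the compounds shown alone.

Compound 1 `Cc1ccc(-c2c(C)nn(-c3nc(-c4ccc(Cl)c(Cl)c4)c(SC(C)C)s3)c2C(=O)O)cc1` is tested in a functional assay on BJAB cells (Homo sapiens) for antiproliferative activity, with a stated time of 4 days (on this read-out higher numbers stand for an effect only at larger amounts of compound and lower numbers for an effect already at smaller amounts), where compound 1 gives 3800 nM; that is the second highest of the three numbers seen so far. Compound 2 `COc1ccc(-c2c(C)nn(-c3nc(-c4ccc(Cl)c(Cl)c4)c(SC(C)C)s3)c2C(=O)O)cc1` gives 2100 nM, and a 1.8-fold lower number from compound 1 to compound 2 (0.26 log units; within the scatter). Compound 3 `COc1cncc(-c2c(C)nn(-c3nc(-c4ccc(Cl)c(Cl)c4)c(SC(C)C)s3)c2C(=O)O)c1` gives 21000 nM, with a 5.5-fold higher number from compound 1 to compound 3 (0.74 log units; beyond the scatter) and a 10-fold higher number from compound 2 to compound 3 (1.00 log units; beyond the scatter). Compound 4 `Cc1nn(-c2nc(-c3ccc(Cl)c(Cl)c3)c(SC(C)C)s2)c(C(=O)O)c1-c1cccc(Cl)c1C` differs from compound 1 in one place: 3-chloro-2-methylphenyl in place of 4-methylphenyl on an aromatic carbon. The ring that enters remains a carbon-only ring, so the step from compound 1 to compound 3, which swapped in a ring with nitrogen, does not bear directly; the step from compound 1 to compound 2 shows that a small swap on that ring stays within the scatter. The expected step is therefore a 1.3-fold lower number from compound 1 to compound 4 (0.10 log units; within the scatter), and compound 4 is estimated at 3000 nM, between 1000 nM and 10000 nM.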

Compound 4, half-maximal effective concentration: 5100 nM
Beside the measured number, compound 4's estimate is 1.7-fold (0.23 log units) below it, within the range that was stated.
By their numbers in this assay, from the lowest: compounds 2, 1 and 4 (each within the scatter of the next, the first and the last beyond it); then compound 3.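

Swapping in 3-chloro-2-methylphenyl gives a 1.3-fold higher number from compound 1 to compound 4 (0.13 log units; within the scatter), so a carbon-only ring carrying a chlorine as well as a methyl does about as well here as 4-methylphenyl. Compared with the nitrogen-containing ring, there is a 4.1-fold lower number from compound 3 to compound 4 (0.61 log units; beyond the scatter), which extends the advantage of carbon-only rings, while a 2.4-fold higher number from compound 2 to compound 4 (0.39 log units; beyond the scatter) is the first gap beyond the scatter among those rings. Nothing measured here gives a reason for these differences. As far as these compounds go, whether the chlorine or the placing of the methyl matters more stays open. So does the effect of a ring carrying an amine.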